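Replacing a thiophene with a three-heteroatom ring

This account rests on a few compounds, and the source may have more. Where it says the series, first, only, none or still open, it means among the compounds named here.

Of the compounds shown here, three sharing one core have been tested in an assay on isolated protein for inhibition of ubiquitin carboxyl-terminal hydrolase 7 (Homo sapiens), with stated times of 30 min and 2 h; on this read-out lower numbers stand for stronger inhibition and higher numbers for weaker inhibition. Compound 1 `Cn1nc2c(=O)n(CC3(O)CCN(Cc4ccc(-c5ccco5)cc4Cl)CC3)cnc2c1-c1ccc(C2(N)CC2)cc1` gives 66.1 nM. Compound 2 `Cn1nc2c(=O)n(CC3(O)CCN(Cc4ccc(-c5ccoc5)cc4Cl)CC3)cnc2c1-c1ccc(CN)cc1` gives 177 nM. Compound 3 `Cn1nc2c(=O)n(CC3(O)CCN(Cc4ccc(-c5cccs5)cc4Cl)CC3)cnc2c1-c1ccc(CN)cc1` gives 38.6 nM, the lowest of the three numbers; its gap to compound 1 lies within the usual scatter, while its gap to compound 2 lies beyond it. Among the compounds with values here, the one directly comparable step is a 4.6-fold lower number from compound 2 to compound 3 (0.66 log units; beyond the scatter), which shows that the ring hanging from the chlorinated aromatic ring does influence the read-out.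

Compound 4 `Cn1nc2c(=O)n(CC3(O)CCN(Cc4ccc(-c5n[nH]c(=O)o5)cc4Cl)CC3)cnc2c1-c1ccc(CN)cc1` continues at the same place. Its difference from compound 3 is a group of 6 heavy atoms (2 carbon, 2 nitrogen, 2 oxygen; one five-membered aromatic ring with 3 hetero atoms) in place of a group of 5 heavy atoms (4 carbon, 1 sulfur; one five-membered aromatic ring with 1 hetero atom), on an aromatic carbon. No measured pair covers a ring with three hetero atoms and a hydrogen-bond donor at this position, so the direction cannot be read off a shown step. What the data do show is that exchanging one five-membered ring for another here moved the number beyond the scatter, so a change of similar size is plausible. Because compound 3 already holds the lowest value at 38.6 nM, the more likely outcome is a higher number. The expected step is a 3.9-fold higher number from compound 3 to compound 4 (0.59 log units; beyond the scatter), and compound 4 is estimated at 150 nM, with a range from 45 nM to 500 nM.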

Compound 4, half-maximal inhibitory concentration: 171 nM
Beside the measured number, compound 4's estimate is 1.1-fold (0.06 log units) below it; the range from low to high includes it.
By their numbers in this assay, from the lowest: compounds 3 and 1 (each within the scatter of the next); then compounds 4 and 2 (each within the scatter of the next).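

In this assay, the new ring with three hetero atoms brings a 4.4-fold higher number from compound 3 to compound 4 (0.65 log units; beyond the scatter), so the low number seen with thiophen-2-yl does not carry over to this five-membered aromatic ring. Set against the furan-3-yl ring, the same new ring gives a 1.0-fold lower number from compound 2 to compound 4 (0.01 log units; within the scatter), so two rings with different atoms and different counts of hydrogen-bond donors and acceptors read alike at this position. The count of hetero atoms therefore does not sort these three compounds: thiophen-2-yl and furan-3-yl each hold one hetero atom yet lie apart beyond the scatter, whereas furan-3-yl and the new ring, with one and three, lie within it.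

Nothing given here explains why the thiophen-2-yl compound stands apart from the other two. Also open, as far as these compounds go, is how other groups at this position would read, such as a plain phenyl ring, a pyridine ring or a carboxylic acid, and whether a ring with two hetero atoms, such as thiazole, would fall nearer compound 3 or compound 4.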